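The source may report more compounds than this note shows. Statements on the series, on what has been measured and on what is new or still open speak of the compounds shown alone.

Values in a functional assay on HL-60 cells (Homo sapiens) for inhibition, read by CCK-8 assay, with a stated time of 48 h (on this read-out lower numbers stand for stronger inhibition and higher numbers for weaker inhibition), so far are as follows.

Compound 1 `COc1ccc(NC(=O)NCCNS(=O)(=O)c2sccc2-c2ccc(C)cc2Oc2ccc(O)c(O)c2)cc1` gives 6100 nM
Compound 2 `O=C(NCCNS(=O)(=O)c1cc(-c2ccccc2Oc2ccc(O)c(O)c2)cs1)Nc1cc(C(F)(F)F)cc(C(F)(F)F)c1` gives 1300 nM

Compound 1 holds the higher of the two numbers, so it is the weaker inhibitor of the pair. Compound 3 `Cc1ccc(-c2ccsc2S(=O)(=O)NCCNC(=O)Nc2cccc([N+](=O)[O-])c2)c(Oc2ccc(O)c(O)c2)c1` keeps the core of compound 1 and changes one place (3-nitrophenyl in place of 4-methoxyphenyl on an amide-type nitrogen), with 3-nitrophenyl in place of 4-methoxyphenyl on an amide-type nitrogen. Going by the values given here, no measured pair isolates this change, and compound 2 differs from compound 1 in more than one place. A modest move toward a lower number is expected in this assay and the estimated step is a 2.0-fold lower number from compound 1 to compound 3 (0.31 log units; beyond the scatter) on that reading. For compound 3 the estimate is 3000 nM with 1100 nM to 8000 nM as its expected range.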

Compound 3, half-maximal inhibitory concentration: 6000 nM
Compound 3: middle estimate off by 2.0-fold (0.30 log units), on the low side; the range from low to high includes it.
By their numbers in this assay, from the lowest: compound 2; then compounds 3 and 1 (each within the scatter of the next).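

In this assay, 3-nitrophenyl in place of 4-methoxyphenyl on an amide-type nitrogen gives a 1.0-fold lower number from compound 1 to compound 3 (0.01 log units; within the scatter). On the core of compound 1, then, this exchange of one substituted phenyl for another leaves the number unchanged, showing that this position tolerates both groups in this read-out. No measured evidence bears on why the two groups read alike.

As far as these compounds go, whether an aminophenyl or carboxyphenyl group on this nitrogen would shift the number remains open. So does whether an unsubstituted phenyl would read the same.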